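Series notes: from compound 2 to compound 3

The source may report more compounds than this note shows. Statements on the series, on what has been measured and on what is new or still open speak of the compounds shown alone.

Measured in a functional assay on HCT-116 cells (Homo sapiens) for antiproliferative activity, read by sulforhodamine B assay, with a stated time of 72 h; a lower number here means a stronger inhibitor, a higher number a weaker inhibitor:
- compound 1 `Cn1ncc(Cl)c1-c1cc(C(=O)N[C@@H]2CN[C@H](CCNS(C)(=O)=O)C[C@H]2c2ccc(F)c(F)c2)oc1Cl`: 920 nM
- compound 2 `Cn1ncc(Cl)c1-c1cc(C(=O)N[C@@H]2CN[C@H](CCN3CCC(O)CC3)C[C@H]2c2ccc(Cl)c(Cl)c2)oc1Cl`: 13700 nM

Of the two measured numbers, compound 2 holds the higher at 13700 nM, making it the weaker inhibitor. Its gap to compound 1 at 920 nM lies beyond the usual scatter.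

Compound 3 `Cn1ncc(Cl)c1-c1cc(C(=O)N[C@@H]2CN[C@H](CC(N)=O)C[C@H]2c2ccc(Cl)c(Cl)c2)oc1Cl` is not yet measured. It differs from compound 2 as follows: carbamoyl in place of (4-hydroxypiperidin-1-yl)methyl on a saturated chain carbon bound to a saturated ring carbon. In words, carbamoyl stands in place of (4-hydroxypiperidin-1-yl)methyl on a saturated chain carbon bound to a saturated ring carbon.

Going by the values given here, two measured compounds set no trend, and no matched pair isolates this change. Compound 1 also lacks the (4-hydroxypiperidin-1-yl)methyl and gives 920 nM, but it differs from compound 2 elsewhere too, so it is only a loose guide. A moderate move toward stronger inhibition is therefore expected, with the estimate amounting to a 3.9-fold lower number from compound 2 to compound 3 (0.59 log units; beyond the scatter). The expected value for compound 3 is 3500 nM, with an estimated range of 900 nM to 13000 nM.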

Compound 3, half-maximal inhibitory concentration: 650 nM
Beside the measured number, compound 3's estimate is 5.4-fold (0.73 log units) above it; measured number below the stated range.
By their numbers in this assay, from the lowest: compounds 3 and 1 (each within the scatter of the next); then compound 2.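

In this assay, going by these compounds alone, the change to carbamoyl from (4-hydroxypiperidin-1-yl)methyl gives a 21-fold lower number from compound 2 to compound 3 (1.32 log units; beyond the scatter) and is the first step that isolates a single place. It shows that the substituent on a saturated chain carbon bound to a saturated ring carbon has a large bearing on this read-out, and that the smaller group gives the stronger inhibitor in this pair. The leaving group has 8 heavy atoms and one six-membered non-aromatic ring, the entering group has 3 heavy atoms and no ring, and no data in hand give a reason for the step.

As far as these compounds go, a single step cannot separate the loss of the ring from the loss of size or from the arrival of the carbamoyl itself, so it remains open which of these goes with the stronger number. A primary amine, a carboxylic acid or a longer chain ending in the same carbamoyl at this place, and a piperidin-1-ylmethyl group without the hydroxyl, would each test a different part of that question.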